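This account rests on a few compounds, and the source may have more. Where it says the series, first, only, none or still open, it means among the compounds named here.

Measured compounds:
compound 1, `CCCSc1nc(N/N=C(\C)c2ccccc2O)c2nnn(Cc3ccco3)c2n1`, 5760 nM
compound 2, `CCCSc1nc(N/N=C/c2cc(OC)c(OC)c(OC)c2)c2nnn(Cc3ccccc3)c2n1`, 4060 nM
compound 3, `C#CCSc1nc(N/N=C/c2cc(OC)c(OC)c(OC)c2)c2nnn(Cc3ccccc3)c2n1`, 6540 nM

These three compounds share a core and were tested in a functional assay on ECa-109 cells (Homo sapiens) for antiproliferative activity, read by MTT assay, with a stated time of 72 h; on this read-out higher numbers stand for weaker inhibition and lower numbers for stronger inhibition. Compound 1 stands second highest of the three numbers; its nearest neighbour is compound 3 and its furthest is compound 2, and both gaps lie within the scatter, so the three compounds cannot be told apart on these numbers.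

Among the measured compounds shown here, the one measured step, a 1.6-fold higher number from compound 2 to compound 3 (0.21 log units; within the scatter), concerns a saturated chain carbon bound to a sulfur and stayed within the scatter.

Compound 4, `CCCSc1nc(N/N=C(\C)c2ccccc2O)c2nnn(Cc3ccccc3)c2n1`, is not yet measured. It differs from compound 1 in one place: phenyl in place of furan-2-yl on a saturated chain carbon bound to an aromatic nitrogen. For the measured compounds named here, no measured step touches this place, so nothing in the data speaks for a change in either direction. Given that the only measured step stayed within the scatter, the expected step is a 1.1-fold lower number from compound 1 to compound 4 (0.04 log units; within the scatter), meaning no shift beyond the scatter. In this assay compound 4 is therefore estimated at 5200 nM, with a range from 2300 nM to 12000 nM.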

Compound 4, half-maximal inhibitory concentration: 11100 nM
Beside the measured number, compound 4's estimate is 2.1-fold (0.33 log units) below it; the measured number falls inside the stated range.
By their numbers in this assay, from the lowest: compounds 2, 1, 3 and 4 (each within the scatter of the next, the first and the last beyond it).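

Among the compounds shown here, this is the first measured change at the saturated chain carbon bound to an aromatic nitrogen. In this assay, phenyl in place of furan-2-yl gives a 1.9-fold higher number from compound 1 to compound 4 (0.28 log units; within the scatter). The swap replaces a five-membered aromatic ring holding one hetero atom with a six-membered ring of carbon only, yet this step stays within the scatter, so these two rings cannot be told apart at this place, and no measurement at hand offers an explanation for the step.

Going by these compounds, only these two aromatic rings appear at this place, so it remains open how a pyridine ring, a saturated cyclohexyl ring or a chain ending in an amine would read. Also open, on these data alone, is whether the same swap would give a similar step with different groups elsewhere on the shared core.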